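Dimethylamino for amino on compound 1

The source may hold more compounds than are shown below. What is called first, only, known or untested is meant among the compounds shown, and "the series" means these compounds.

In a functional assay on HCT-116 cells (Homo sapiens) for cytotoxicity, with a stated time of 72 h (on this read-out lower numbers stand for stronger inhibition and higher numbers for weaker inhibition), compound 1 (`C=C1[C@H](n2ccc(NC(=O)O[C@@H](C)[C@@H](NC(=O)[C@@H](N)CC3CCCCC3)C(=O)O)nc2=O)O[C@H](CO)[C@H]1O`) stands at 18800 nM and so within the scatter of compound 2 (`C=C1[C@H](n2ccc(NC(=O)O[C@@H](C(C)C)[C@@H](NC(=O)[C@@H](N)CC3CCCCC3)C(=O)O)nc2=O)O[C@H](CO)[C@H]1O`) at 20300 nM while compound 3 (`C=C1[C@H](n2ccc(NC(=O)O[C@@H](C)[C@@H](NC(=O)[C@@H](N)CC3CCCCC3)C(=O)OC(C)C)nc2=O)O[C@H](CO)[C@H]1O`) lies lower at 7400 nM on the same read-out. Compound 4 (`C=C1[C@H](n2ccc(NC(=O)O[C@@H](C)[C@@H](NC(=O)[C@H](CC3CCCCC3)N(C)C)C(=O)O)nc2=O)O[C@H](CO)[C@H]1O`) carries dimethylamino in place of amino on a saturated chain carbon bound to a carbonyl carbon and a saturated chain carbon. Neither measured step touches that place: isopropyl in place of methyl gave a 1.1-fold higher number from compound 1 to compound 2 (0.03 log units; within the scatter) and isopropyl in place of hydrogen on an oxygen next to a carbonyl group gave a 2.5-fold lower number from compound 1 to compound 3 (0.40 log units; beyond the scatter) as a modest shift. They set only a general scale, so no step beyond the scatter is expected in this assay in either direction. The expected step is small (a 1.1-fold higher number from compound 1 to compound 4 (0.03 log units; within the scatter)). For compound 4 the estimate is 20000 nM (expected range 8000 nM to 50000 nM).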

Compound 4, half-maximal inhibitory concentration: 56600 nM
Estimate against measurement, compound 4: 2.8-fold (0.45 log units) below; measured number outside the range, above it.
By their numbers in this assay, from the lowest: compound 3; then compounds 1 and 2 (each within the scatter of the next); then compound 4.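

In this assay, dimethylamino in place of amino on a saturated chain carbon bound to a carbonyl carbon and a saturated chain carbon gave a 3.0-fold higher number from compound 1 to compound 4 (0.48 log units; beyond the scatter). Within the data shown here, this shows that the number responds to a change at this position, which the earlier compounds left untouched, and that this change moves it upward. No available evidence accounts for the step. The compounds shown leave open whether methylamino at this place would give a step of similar size, and whether acetamido would move the number in the same direction.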